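The compounds below may be only part of what the source reports. "The series", "measured", "known", "first", "only" and "open" are said of these compounds alone.

Measured so far:
compound 1, `CC(=O)c1cc(-c2ccccc2)cc2cc(-c3ccccc3)[nH]c12`: 72.3%
compound 2, `CC(=O)c1cc(-c2ccccc2)cc2cc(-c3ccc(F)cc3)[nH]c12`: 91.1%

In a functional assay on HeLa cells (Homo sapiens) for cytotoxicity, read by MTT assay, with a stated time of 2 days, tested at 0.1 uM (a lower number here means a stronger effect, a higher number a weaker effect of the compound at the concentration tested), compound 2 gives the higher of the two numbers, and its nearest neighbour is compound 1, separated by the step of a number 18.8 percentage points higher from compound 1 to compound 2 (beyond the scatter). Compound 3, `COc1ccc(-c2cc3cc(-c4ccccc4)cc(C(C)=O)c3[nH]2)cc1`, differs from compound 2 in one place: methoxy in place of fluoro on an aromatic carbon. Among the compounds with values here, only one measured step bears on this change, and only loosely: the step from hydrogen to fluoro, a number 18.8 percentage points higher from compound 1 to compound 2 (beyond the scatter), which was modest. Within the data shown here, no measured pair shows what a methoxy does in this assay. Because a number 18.8 percentage points higher from compound 1 to compound 2 (beyond the scatter) was itself small, the replacement of fluoro by methoxy is expected to move the read-out little, with a slight fall toward compound 1 being the more likely direction, and a step within the scatter is entirely possible. Compound 3 is therefore estimated at 84%, in the range 66% to 100%. This estimate corresponds to an expected step of a number 7.1 percentage points lower from compound 2 to compound 3 (within the scatter).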

Compound 3, a percentage reported as activity, at one concentration (the size of the read-out at that concentration, not a potency): 80.5%
Compound 3: the middle estimate sits 3.5 percentage points above what was measured; measured number inside the range.
By their numbers in this assay, from the lowest: compounds 1 and 3 (each within the scatter of the next); then compound 2.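

In this assay, the aromatic carbon that carries fluoro in compound 2 now shows that the read-out depends on which group sits there, not merely on whether hydrogen has been replaced, with the change from 4-fluorophenyl to 4-methoxyphenyl giving a number 10.6 percentage points lower from compound 2 to compound 3 (beyond the scatter). Measured against the hydrogen of compound 1, methoxy gives a number 8.2 percentage points higher from compound 1 to compound 3 (within the scatter), so compound 3 cannot be told apart from compound 1, while compound 2 stands apart from both. Nothing available here accounts for the difference between fluoro and methoxy at this carbon.

Still open, going by these compounds, is whether chloro, an amine or a longer chain such as ethoxy at this carbon would group with fluoro or with methoxy and hydrogen. The compounds shown also leave open whether these groups would give the same order on the other phenyl ring.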